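The source may hold more compounds than are shown below. What is called first, only, known or untested is meant among the compounds shown, and "the series" means these compounds.

Measured compounds:
compound 1 `CSc1nccc(N2CCC(N(C)Cc3c(F)cccc3Cl)CC2)n1` — 1040 nM
compound 2 `CSc1nccc(N2CCC(N(C)Cc3ccc(C#N)cc3)CC2)n1` — 1410 nM

Both numbers come from a functional assay on BT-474 cells (Homo sapiens) for inhibition, read by luminescence, with a stated time of 72 h; on this read-out lower numbers stand for stronger inhibition and higher numbers for weaker inhibition. Compound 2 carries the higher of the two numbers, but the gap is small: a 1.4-fold higher number from compound 1 to compound 2 (0.13 log units; within the scatter). On the numbers shown the two compounds are not separated.

Compound 3 `CSc1nccc(N2CCC(N(C)Cc3c(Cl)cccc3Cl)CC2)n1` is not yet measured. It differs from compound 2 in one place: 2,6-dichlorophenyl in place of 4-cyanophenyl on a saturated chain carbon bound to an amine nitrogen. Among the compounds with values here, the only measured step that bears on this change is a 1.4-fold higher number from compound 1 to compound 2 (0.13 log units; within the scatter), in which a halogenated phenyl gave way to 4-cyanophenyl with no shift beyond the scatter. Compound 3 returns to a halogenated phenyl of the same kind as the 2-chloro-6-fluorophenyl of compound 1, which gives 1040 nM. No shift beyond the scatter is therefore expected in this assay, and the expected step is a 1.4-fold lower number from compound 2 to compound 3 (0.15 log units; within the scatter). Compound 3 is estimated at 1000 nM, with a range from 400 nM to 2500 nM.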

Compound 3, half-maximal inhibitory concentration: 780 nM
Beside the measured number, compound 3's estimate is 1.3-fold (0.11 log units) above it, within the range that was stated.
By their numbers in this assay, from the lowest: compounds 3, 1 and 2 (each within the scatter of the next).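

In this assay, 2,6-dichlorophenyl and 4-cyanophenyl on a saturated chain carbon bound to an amine nitrogen are not separated (a 1.8-fold lower number from compound 2 to compound 3 (0.26 log units; within the scatter)), so the flat result at this position now holds with a second halogenated phenyl in the comparison. Chloro in place of fluoro on an aromatic carbon also gives no separation (a 1.3-fold lower number from compound 1 to compound 3 (0.12 log units; within the scatter)), which is the direct reading of that halogen exchange on this phenyl group. No measured data bear on the reason for these numbers.

From the compounds shown here alone, all three compounds keep the shared core and a substituted phenyl at this place, so the outcome with a pyridine, a cyclohexyl group or a carboxylic acid there remains open. The methylthio group is also the same throughout, and whether an amine in its place would move the number beyond the scatter is an open question.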